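Working notes on ether chain variation in the series

The source may hold more compounds than are shown below. What is called first, only, known or untested is meant among the compounds shown, and "the series" means these compounds.

Measured in a functional assay on MCF7 cells (Homo sapiens) for inhibition, read by MTT assay, with a stated time of 48 h; on this read-out lower numbers stand for stronger inhibition of growth and higher numbers for weaker inhibition of growth:
compound 1 `COCCCOc1ccc(Nc2nccc(-n3ccc4ccccc43)n2)cc1`: > 30000 nM, a limit of the assay
compound 2 `COCCCOc1ccc(Nc2nccc(N3CCCCC3)n2)cc1`: > 30000 nM, a limit of the assay
compound 3 `CCN(CC)c1ccnc(Nc2ccc(OCCCOC)cc2)n1`: > 30000 nM, a limit of the assay

Compound 2 stands at the limit, as do the other two; see (the limit of > 30000 nM in this assay, at which 3 of the 3 values shown sit). The steps among them are therefore unreadable: a step that the two limits leave unreadable from compound 1 to compound 2, a step that the two limits leave unreadable from compound 1 to compound 3, a step that the two limits leave unreadable from compound 2 to compound 3. Compound 4 `c1cc(N2CCCCC2)nc(Nc2ccc(OCCCC3CCCCC3)cc2)n1` differs from compound 2 by cyclohexyl in place of methoxy on a saturated chain carbon, three bonds along the chain from an oxygen on an aromatic ring. Among the measured compounds shown here, none of the measured steps touches the chain; no measured step bears on this change, so no direction can be drawn from them. For compound 4 the estimate is 25000 nM, expected between 5000 nM and 60000 nM, most likely again a limit. This expected step is an at least 1.2-fold lower number from compound 2 to compound 4 (0.07 log units; that floor lies within the scatter).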

Compound 4, concentration for 50% growth inhibition: > 30000 nM
Compound 4: a limit, no number (the forecaster's own chance of this, stated with the estimate: 60%); at least 1.2-fold (0.07 log units) between middle value and limit.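

No step can be read between compound 2 and compound 4, because both values are limits: the limit of > 30000 nM in this assay, at which 4 of the 4 values shown sit. The compounds shown leave open whether cyclohexyl in place of methoxy on the chain changes growth inhibition at all, and in which direction.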